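The compounds below may be only part of what the source reports. "The series", "measured", "known", "first", "only" and "open" are said of these compounds alone.

Measured so far:
Compound 1, `COc1cc2c(Oc3ccc(NC(=O)c4nn(-c5ccccc5C)c(=O)cc4C)cc3F)ccnc2cc1OCCCN1CCC(C)CC1`: 1460 nM
Compound 2, `COc1cc2c(Oc3ccc(NC(=O)c4nn(-c5ccc(Cl)cc5)c(=O)cc4C)cc3F)ccnc2cc1OCCCN1CCC(C)CC1`: 210 nM

In a functional assay on A549 cells (Homo sapiens) for inhibition, read by MTT assay, with a stated time of 72 h (a higher number here means a weaker inhibitor, a lower number a stronger inhibitor), compound 2 gives 210 nM, the lowest of the two numbers measured. The nearest is compound 1, which gives 1460 nM. Within the data shown here, the only measured step, a 7.0-fold lower number from compound 1 to compound 2 (0.84 log units; beyond the scatter), exchanges the whole aryl group on the aromatic nitrogen. Compound 3, `COc1cc2c(Oc3ccc(NC(=O)c4nn(-c5ccc(Cl)cc5Cl)c(=O)cc4C)cc3F)ccnc2cc1OCCCN1CCC(C)CC1`, keeps the 4-chlorophenyl of compound 2 and adds one more substituent: chloro in place of hydrogen on an aromatic carbon, ortho to a large group and meta to a chloro group. Among the measured compounds shown here, no measured step adds a chloro to an aryl that is otherwise unchanged, so the step from compound 1 to compound 2 bears on this change only loosely. It shows that the aryl group matters and that the 2-methylphenyl gave the higher number. The expected change, a 2.0-fold higher number from compound 2 to compound 3 (0.30 log units; within the scatter), is therefore a somewhat higher number, possibly within the scatter. Compound 3 is estimated at 420 nM, within the range 120 nM to 1500 nM.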

Compound 3, half-maximal inhibitory concentration: 200 nM
The estimate for compound 3 lay 2.1-fold (0.32 log units) above the measured number, within the range that was stated.
By their numbers in this assay, from the lowest: compounds 3 and 2 (each within the scatter of the next); then compound 1.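

In this assay, adding a chloro on an aromatic carbon, ortho to a large group, gives a 1.1-fold lower number from compound 2 to compound 3 (0.02 log units; within the scatter), so this position accepts a chloro with no change that can be told from the scatter. The step to 2,4-dichlorophenyl from 2-methylphenyl gives a 7.3-fold lower number from compound 1 to compound 3 (0.86 log units; beyond the scatter), which shows that a group at this place on the aryl ring does not by itself bring the higher number of compound 1. Nothing available explains these numbers.

Compound 1 and compound 3 differ at two places on the aryl ring, so the effect of methyl against chloro at this position stays unresolved, and a 4-chloro-2-methylphenyl compound would separate the two. Also open, from the compounds shown here alone, is how this position would respond to a methoxy, an amine or a carboxylic acid.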